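From Cyclohexyloxy to Cyclohexylmethoxy on the Shared Core

The compounds below may be only part of what the source reports. "The series", "measured", "known", "first", "only" and "open" are said of these compounds alone.

Of the compounds shown here, two sharing a core have been measured in a functional assay on HEK293 cells for negative allosteric modulation of metabotropic glutamate receptor 5 (Homo sapiens), read by FLIPR and calcium flux; on this read-out higher numbers stand for weaker inhibition and lower numbers for stronger inhibition. Compound 1 `Cc1cccc(NC(=O)c2nn(C)c(-c3cc(F)cc(F)c3)c2C)n1` carries a 3,5-difluorophenyl group and in this assay gives 5.3 nM. Compound 2 `Cc1cccc(NC(=O)c2nn(C)c(OC3CCCCC3)c2C)n1`, in which cyclohexyloxy takes the place of that group, gives 92 nM in this assay. Going by the values given here, that single change brought a 17-fold higher number from compound 1 to compound 2 (1.24 log units; beyond the scatter), so compound 2 stands as the higher of the two numbers, with compound 1 as its only neighbour at the lower end.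

Compound 3 `Cc1cccc(NC(=O)c2nn(C)c(OCC3CCCCC3)c2C)n1` has not been measured. It differs from compound 2 by cyclohexylmethyl in place of cyclohexyl on an oxygen on an aromatic ring. Among the compounds with values here, no measured step bears directly on this kind of change: the one step in hand, a 17-fold higher number from compound 1 to compound 2 (1.24 log units; beyond the scatter), compares an aromatic group with an ether and tells nothing about lengthening the ether. The expectation therefore rests on compound 2 alone. From compound 2 a step within or near the scatter is expected, in no firm direction, a 1.3-fold higher number from compound 2 to compound 3 (0.12 log units; within the scatter). Compound 3 is accordingly estimated at 120 nM in this assay, with a range from 40 nM to 400 nM.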

Compound 3, half-maximal inhibitory concentration: 1300 nM
Compound 3: middle estimate off by 11-fold (1.03 log units), on the low side; the whole stated range lies below it.
By their numbers in this assay, from the lowest: compound 1; then compound 2; then compound 3.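

At this position the ether is far less tolerant than the opening pair could show: in this assay, cyclohexylmethyl in place of cyclohexyl on an oxygen on an aromatic ring brought a 14-fold higher number from compound 2 to compound 3 (1.15 log units; beyond the scatter) even though the ring type and the count of hydrogen-bond donors and acceptors stayed the same, and the group grew from 6 to 7 heavy atoms. The earlier step had compared an aromatic group with an ether, whereas this one shows that a change within the ether alone can lie well beyond the scatter, and cyclohexylmethoxy in place of 3,5-difluorophenyl on an aromatic carbon gives a 250-fold higher number from compound 1 to compound 3 (2.39 log units; beyond the scatter) as the widest step among the three compounds. Nothing measured alongside these values accounts for the change in the ether.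

The compounds shown leave open whether a longer chain, such as cyclohexylethoxy, would carry the rise further, or whether a smaller ether, such as methoxy or cyclopentyloxy, would bring the number down. They also leave open how phenoxy or benzyloxy would compare with these saturated ethers, and whether an amine linking the cyclohexyl ring would behave as the oxygen does.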